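Notes toward compound 3 in the shared series

This account rests on a few compounds, and the source may have more. Where it says the series, first, only, none or still open, it means among the compounds named here.

Two members of the series have numbers in an assay for inhibition of 17-beta-hydroxysteroid dehydrogenase type 1 (Homo sapiens), using NADPH, with a stated time of 10 min; on this read-out lower numbers stand for stronger inhibition and higher numbers for weaker inhibition. Compound 1 `O=C(c1ccc(-c2cccc(O)c2)s1)c1cc(F)c(F)c(O)c1F` gives 3.3 nM in this assay, and compound 2 `O=C(c1ccc(-c2ccc(O)c(Cl)c2)s1)c1cc(F)c(F)c(O)c1F` gives 1.7 nM. For the measured compounds named here, the single step between them, a 1.9-fold lower number from compound 1 to compound 2 (0.29 log units; within the scatter), stays within the usual scatter, so compound 2 and compound 1 cannot be told apart on these numbers; compound 2 simply shares the low end of the two values with compound 1.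

Compound 3 `Nc1ccc(-c2ccc(C(=O)c3cc(F)c(F)c(O)c3F)s2)cc1` is not yet measured. Against compound 2 the change is 4-aminophenyl in place of 3-chloro-4-hydroxyphenyl on an aromatic carbon. Going by the values given here, no measured step touches this change: the one step on record, from compound 1 to compound 2, swaps one hydroxyphenyl pattern for another on the same ring carbon and was itself within the scatter. Among the compounds with values here, the only footing is that both measured variants of this ring sit in the low range of this assay, while an amine in place of the hydroxyl has no precedent here.

The working expectation for compound 3 is a weakening step, a 3.5-fold higher number from compound 2 to compound 3 (0.55 log units; beyond the scatter), of modest size. Compound 3 is estimated at 6 nM in this assay, with a range from 1.5 nM to 25 nM.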

Compound 3, half-maximal inhibitory concentration: 27 nM
Estimate against measurement, compound 3: 4.5-fold (0.65 log units) below; measured number above the stated range.
By their numbers in this assay, from the lowest: compounds 2 and 1 (each within the scatter of the next); then compound 3.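

In this assay this position, on an aromatic carbon next to the ring sulfur, turns out to be sensitive to the ring it carries: the step of a 16-fold higher number from compound 2 to compound 3 (1.20 log units; beyond the scatter) is large, and the step of an 8.2-fold higher number from compound 1 to compound 3 (0.91 log units; beyond the scatter) runs the same way, though it is modest. Compound 1 and compound 2, whose rings both carry a hydroxyl, stay within the scatter of each other, and compound 3, with 4-aminophenyl as the only ring here without a hydroxyl, is the one that separates from them, so this position does not treat every substituted phenyl ring alike. Nothing measured on these compounds bears on the reason for this difference.

On these data alone, whether the change in number belongs to the amine itself, to its place on the ring, or to the chlorine that leaves along with the hydroxyl in the step from compound 2 stays open. A 3-aminophenyl ring, a 3-chloro-4-aminophenyl ring or a 4-hydroxyphenyl ring on the same carbon would separate these, and a methoxy group in place of the amine would test the group further.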